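This account rests on a few compounds, and the source may have more. Where it says the series, first, only, none or still open, it means among the compounds named here.

Three sulfonamides built around a shared benzoxazole-bearing core have been tested in an ADME assay on HEK293 cells (Homo sapiens) for cytotoxicity, read by resazurin assay, with a stated time of 48 h; on this read-out higher numbers stand for lower toxicity in this test and lower numbers for higher toxicity in this test. Compound 1, `O=S(=O)(Nc1ccc(-c2nc3ccccc3o2)cc1)c1ccc(Cl)c(C(F)(F)F)c1`, carries a chloro- and trifluoromethyl-substituted phenyl ring on its sulfonyl sulfur and gives 69000 nM in this assay. Compound 2, `O=S(=O)(Nc1ccc2oc(-c3ccccc3)nc2c1)c1ccccc1F`, places the sulfonamide on the other side of the core and carries a fluorophenyl group; in this assay compound 2 gives 72000 nM. Compounds 1 and 2 lie within the usual scatter of each other, so no order between them can be read from these numbers. Compound 3, `O=S(=O)(Nc1ccc(-c2nc3ccccc3o2)cc1)c1cccs1`, carries a thiophen-2-yl group on the sulfonyl sulfur. In this assay compound 3 gives only a limit, > 100000 nM, which is one of the values described by the limit of > 100000 nM in this assay, at which 1 of the 3 values shown sits; no number is known for it.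

The next compound, compound 4, `Cc1cccc(S(=O)(=O)Nc2ccc(-c3nc4ccccc4o3)cc2)c1`, differs from compound 3 by one change: 3-methylphenyl in place of thiophen-2-yl on a sulfonyl sulfur. For the measured compounds named here, no step between measured compounds matches this exchange, so the expectation rests on the three values shown. Because compound 1 gives 69000 nM with another aromatic group on the sulfonyl sulfur, and because compound 2 gives 72000 nM with another such group, compound 4 is expected to stay in the same weakly toxic region, with a step expected to be about an at least 1.1-fold lower number from compound 3 to compound 4 (0.07 log units; that floor lies within the scatter). Compound 4 may again end at the limit of this assay, as compound 3 does. Compound 4 is therefore estimated at 85000 nM, with a range from 40000 nM to 200000 nM in this assay.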

Compound 4, half-maximal cytotoxic concentration: > 100000 nM
Compound 4 was reported as a limit (the forecaster's own chance of this, stated with the estimate: 45%); at least 1.1-fold (0.07 log units) between middle value and limit.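

Compound 3 and compound 4 both end at a limit rather than at a number, so no step from one to the other can be read: the limit of > 100000 nM in this assay, at which 2 of the 4 values shown sit.

The compounds shown leave open whether 3-methylphenyl in place of thiophen-2-yl on a sulfonyl sulfur changes the half-maximal cytotoxic concentration at all, and if it does, in which direction and by how much.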